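This account rests on a few compounds, and the source may have more. Where it says the series, first, only, none or still open, it means among the compounds named here.

Measured so far:
compound 1 `CC1CCN(c2cc(C(F)(F)F)ccc2CNC(=O)C(C)c2ccc(NS(C)(=O)=O)c(F)c2)CC1`: 0.9 nM
compound 2 `CCCOc1cc(C(F)(F)F)ccc1CNC(=O)C(C)c1ccc(NS(C)(=O)=O)c(F)c1`: 2 nM
compound 3 `CC(C(=O)NCc1ccc(C(F)(F)F)cc1F)c1ccc(NS(C)(=O)=O)c(F)c1`: 68.7 nM

In an assay on CHO cells for antagonist activity at transient receptor potential cation channel subfamily V member 1 (Homo sapiens), read by FLIPR (on this read-out lower numbers stand for stronger inhibition and higher numbers for weaker inhibition), compound 3 holds the highest of the three numbers; the nearest is a 34-fold higher number from compound 2 to compound 3 (1.54 log units; beyond the scatter), the furthest a 76-fold higher number from compound 1 to compound 3 (1.88 log units; beyond the scatter). Compound 4 `CCCCCc1cc(C(F)(F)F)ccc1CNC(=O)C(C)c1ccc(NS(C)(=O)=O)c(F)c1` differs from compound 3 by pentyl in place of fluoro on an aromatic carbon. For the measured compounds named here, the steps that bear on it are those in which the fluoro was replaced by a larger group at this carbon: a 76-fold higher number from compound 1 to compound 3 (1.88 log units; beyond the scatter) and a 34-fold higher number from compound 2 to compound 3 (1.54 log units; beyond the scatter), both large and in the same direction, while a 2.2-fold higher number from compound 1 to compound 2 (0.35 log units; beyond the scatter) is only modest. Pentyl is a chain at the same carbon as propoxy in compound 2, so a large step downward is expected, of roughly the size seen from compound 2. The expected step is a 23-fold lower number from compound 3 to compound 4 (1.36 log units; beyond the scatter). Compound 4 is therefore estimated at 3 nM, within 1 nM to 12 nM.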

Compound 4, inhibition constant: 0.4 nM
Estimate against measurement, compound 4: 7.5-fold (0.88 log units) above, and the stated range ends above it.
By their numbers in this assay, from the lowest: compound 4; then compound 1; then compound 2; then compound 3.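

In this assay, pentyl in place of fluoro gives a 170-fold lower number from compound 3 to compound 4 (2.23 log units; beyond the scatter) at this aromatic carbon, so a chain of carbon alone is enough for high potency here. The oxygen of propoxy and the nitrogen of 4-methylpiperidin-1-yl are not required: pentyl gives a 5.0-fold lower number from compound 2 to compound 4 (0.70 log units; beyond the scatter) and also a 2.3-fold lower number from compound 1 to compound 4 (0.35 log units; beyond the scatter) in this series, leaving compound 4 the most potent of the four. Nothing given here accounts for these steps.

As far as these compounds go, how far potency holds with a longer chain such as heptyl remains open, as does the effect of an amine or a carboxylic acid at the chain end.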